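The source may hold more compounds than are shown below. What is called first, only, known or untested is meant among the compounds shown, and "the series" means these compounds.

The set holds three measured ureas: compound 1 `CC(C)c1ccccc1NC(=O)N[C@H](C)c1ccccc1`, compound 2 `C[C@@H](NC(=O)Nc1cccc(C(F)(F)F)c1)c1ccccc1` and compound 3 `C[C@H](NC(=O)Nc1cccc(C(F)(F)F)c1)c1ccccc1`. In an ADME assay on the whole organism with Oryza sativa as the target, tested at 0.1 uM (on this read-out higher numbers stand for a weaker effect at the one concentration tested and lower numbers for a stronger effect), compound 1 gives 103%, compound 2 gives 82% and compound 3 gives 94%. Compound 2 thus stands lowest of the three, so its effect at the concentration tested is the strongest. Going by the values given here, the only single-change step among the measured compounds is a number 12 percentage points higher from compound 2 to compound 3 (beyond the scatter), a difference that rests on (the fact that compounds 2 and 3 differ only in the configuration as drawn). Compound 4 `C[C@@H](NC(=O)Nc1cccc(Br)c1)c1ccccc1` differs from compound 2 by bromo in place of trifluoromethyl on an aromatic carbon. Among the compounds with values here, no measured step concerns a change of this kind, so no step beyond the scatter is expected in this assay. Compound 4 is therefore expected to give about 86%, within 70% to 102%. That expectation amounts to a number 4 percentage points higher from compound 2 to compound 4 (within the scatter).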

Compound 4, a percentage reported as activity, at one concentration (the size of the read-out at that concentration, not a potency): 100%
Beside the measured number, compound 4's estimate is 14 percentage points below it; the measured number falls inside the stated range.
By their numbers in this assay, from the lowest: compound 2; then compounds 3, 4 and 1 (each within the scatter of the next).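

In this assay, the step of a number 18 percentage points higher from compound 2 to compound 4 (beyond the scatter) shows that the substituent on this aromatic carbon also moves the read-out, whereas the earlier step concerned only configuration. With the configuration as drawn in compound 2 held fixed, bromo does not stand in for trifluoromethyl at this place. Nothing available here accounts for this step.

Still open, from the compounds shown here alone, is how a chloro, methoxy or nitrile group would read at the same aromatic carbon. Also open, going by these compounds, is whether the step from trifluoromethyl to bromo would be of similar size with the stereocentre drawn S.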